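The source may report more compounds than this note shows. Statements on the series, on what has been measured and on what is new or still open speak of the compounds shown alone.

Measured so far:
compound 1 `Cc1cccc(C#Cc2nc3c(s2)C(=O)NCC3)c1`: > 10000 nM
compound 2 `CC(C)CN1CCc2nc(C#Cc3ccccc3)sc2C1`: > 10000 nM

In an assay on HEK293 cells for positive allosteric modulation of metabotropic glutamate receptor 5 (Homo sapiens), read by FLIPR, with a stated time of 1 h (a lower number here means that less compound is needed, a higher number that more compound is needed for the effect), compound 2 gives > 10000 nM, which is a limit of the assay and not a number. Compound 1 also gives only a limit, > 10000 nM. For the measured compounds named here, the whole of the evidence is therefore (the limit of > 10000 nM in this assay, at which 2 of the 2 values shown sit), and no measured step exists to scale from. Compound 3 `CC1CC1C(=O)N1CCc2nc(C#Cc3ccccc3)sc2C1` carries (2-methylcyclopropyl)carbonyl in place of isobutyl on an amine nitrogen in a ring. With no anchor, the expected step from compound 2 to compound 3 is an at least 5.0-fold lower number from compound 2 to compound 3 (0.69 log units; beyond the scatter), an improvement taken as a loose guess. Compound 3 is estimated at 2000 nM, with a range of 200 nM to 15000 nM.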

Compound 3, half-maximal effective concentration: 9.4 nM
Compound 3: middle estimate off by 210-fold (2.33 log units), on the high side, outside the stated range (below it).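

In this assay, (2-methylcyclopropyl)carbonyl in place of isobutyl on an amine nitrogen in a ring gives an at least 1000-fold lower number from compound 2 to compound 3 (3.02 log units; beyond the scatter). Going by these compounds, compound 2 gives > 10000 nM, which is a limit of the assay and not a number, and the full size of the step stays unknown. For the compounds shown here, the group on this nitrogen can thus decide between a limit and a measured value, and compound 3 holds the only value shown that is not a limit.

The change brings in the carbonyl and the methylcyclopropyl ring together, and the compounds shown do not separate them. An acetyl or a (2-methylcyclopropyl)methyl group on the same nitrogen would divide the step between the two.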